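A furan-2-yl to phenyl exchange among inactive compounds

The source may hold more compounds than are shown below. What is called first, only, known or untested is meant among the compounds shown, and "the series" means these compounds.

Compound 1 `Cc1ncnc2c1c(-c1cccs1)cn2[C@@H]1O[C@H](CO)[C@@H](O)[C@H]1O` gives > 20000 nM (a limit)
Compound 2 `Nc1nc(N)c2c(-c3ccco3)cn([C@@H]3O[C@H](CO)[C@@H](O)[C@H]3O)c2n1` gives > 20000 nM (a limit)
Compound 3 `Cc1nc(N)c2c(-c3ccco3)cn([C@@H]3O[C@H](CO)[C@@H](O)[C@H]3O)c2n1` gives > 100000 nM (a limit)

In a functional assay on CCRF-CEM cells (Homo sapiens), read by MTT assay, with a stated time of 72 h (on this read-out lower numbers stand for stronger inhibition and higher numbers for weaker inhibition), compound 3 gives > 100000 nM as a limit and not as a number. The values of the other two compounds are limits too, so none of the three has a measured potency.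

Compound 4 `Cc1nc(N)c2c(-c3ccccc3)cn([C@@H]3O[C@H](CO)[C@@H](O)[C@H]3O)c2n1` carries phenyl in place of furan-2-yl on an aromatic carbon of a five-membered aromatic ring with 1 nitrogen, and the change counts as phenyl in place of furan-2-yl on an aromatic carbon in full. Among the measured compounds shown here, the one measured step that the two limits leave unreadable from compound 2 to compound 3 is methyl in place of amino on an aromatic carbon and has no readable size. For the measured compounds named here, no measured step makes the exchange at hand.

The expectation therefore rests on compound 3 with its limit of > 100000 nM as the starting point. No step beyond the scatter is expected in this assay and another limit is the likeliest report. The expected step of a number no higher from compound 3 to compound 4 (the limit leaves the size open) is only a rough estimate set against a limit. The estimated value for compound 4 is 100000 nM with an expected range from 20000 nM to 200000 nM as its span.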

Compound 4, half-maximal inhibitory concentration: > 20000 nM
Compound 4 ended at the assay's limit; the forecaster's own chance of this, stated with the estimate: 85%; the middle value is on the limit's open side.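

Compound 3 and compound 4 are both reported only as limits in this assay, so no step can be read for the exchange of furan-2-yl for phenyl. With all four values shown being limits, the compounds leave open how the two groups compare in potency.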